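The compounds below may be only part of what the source reports. "The series", "measured", "known", "first", "only" and "open" are said of these compounds alone.

Among the measured compounds shown here, compound 1 `C#CCN(Cc1ccc2nc(C)nc(O)c2c1)c1ccc(C(=O)N[C@@H](CCC(=O)O)C(=O)N[C@@H](CCC(=O)O)C(=O)O)cc1` is one of three compounds measured in a functional assay for inhibition, with Mus musculus as the target (on this read-out lower numbers stand for stronger inhibition and higher numbers for weaker inhibition), where compound 1 gives 2700 nM, the lowest of the three numbers. Compound 2 `C#CCN(Cc1ccc2nc(C)nc(O)c2c1)c1ccc(C(=O)N[C@@H](CCC(=O)O)C(=O)N2CCCC2C(=O)O)cc1` gives 10000 nM and compound 3 `C#CCN(Cc1ccc2nc(C)nc(O)c2c1)c1ccc(C(=O)N[C@@H](CCC(=O)O)C(=O)NC(C)(C)C(=O)O)cc1` gives 7100 nM; the steps of a 3.7-fold higher number from compound 1 to compound 2 (0.57 log units; beyond the scatter) and a 2.6-fold higher number from compound 1 to compound 3 (0.42 log units; beyond the scatter) both raised the number modestly. Compound 4 `C#CCN(Cc1ccc2nc(C)nc(O)c2c1)c1ccc(C(=O)N[C@@H](CC(C)C(=O)O)C(=O)N[C@@H](CCC(=O)O)C(=O)O)cc1` differs from compound 1 by methyl in place of hydrogen on a saturated chain carbon bound to a carbonyl carbon and a saturated chain carbon. For the measured compounds named here, no measured step alters this part of the molecule, so the two steps bear on it only indirectly, by showing that changes elsewhere in compound 1 have so far raised the number rather than lowered it. Compound 4 is therefore expected to show a 1.5-fold higher number from compound 1 to compound 4 (0.17 log units; within the scatter), an estimate of 4000 nM with a range from 1500 nM to 12000 nM.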

Compound 4, half-maximal inhibitory concentration: 3400 nM
Compound 4: the middle estimate sits 1.2-fold (0.07 log units) above what was measured; low and high end bracket the measured number.
By their numbers in this assay, from the lowest: compounds 1 and 4 (each within the scatter of the next); then compounds 3 and 2 (each within the scatter of the next).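

In this assay, among the compounds shown here, the step of a 1.3-fold higher number from compound 1 to compound 4 (0.10 log units; within the scatter) is the first measured change at this saturated chain carbon, and it lies within the scatter. Unlike the two earlier steps from compound 1, both beyond the scatter, it shows one change to compound 1 that leaves the number indistinguishable from that of compound 1. No available evidence bears on this result. From the compounds shown here alone, whether an ethyl chain or an amine on the same carbon would also stay within the scatter remains open, as does whether methyl there would give the same result in compound 2 or compound 3.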